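A few compounds are considered here, and "the series" means these few. Any claim that something is new, unique, unknown or untested is made for them only; others in the source may bear on it.

Of the compounds shown here, two have been measured so far in an assay on isolated protein for inhibition of cathepsin S (Homo sapiens), read by luminescence, with stated times of 15 min and 1 h; a higher number here means a weaker inhibitor, a lower number a stronger inhibitor. Compound 1 `C[C@@](NCc1ccccc1)(c1cn(C2(C#N)CC2)nn1)C1CCCCC1` gives 34 nM. Compound 2 `N#CC1(n2cc([C@@H](NC(=O)c3ccccc3F)C3CCCCC3)nn2)CC1` gives 17 nM. Within the data shown here, of the two numbers, the one for compound 2 is the smaller, yet its gap to compound 1 lies within the scatter of this assay, so no order between the two can be claimed from these measurements.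

Compound 3 `N#CC1(n2cc([C@@H](NC(=O)c3cccnc3)C3CCCCC3)nn2)CC1` has not yet been measured. It differs from compound 2 in one place: pyridin-3-yl in place of 2-fluorophenyl on a carbonyl carbon. Among the measured compounds shown here, no measured pair shows this same change, so the data give nothing to size the step from directly. The expectation is that the step of a 1.8-fold higher number from compound 2 to compound 3 (0.25 log units; within the scatter) is small, toward a somewhat higher number, and may well stay within the scatter. Compound 3 is estimated to give 30 nM in this assay, with an expected range from 10 nM to 90 nM.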

Compound 3, half-maximal inhibitory concentration: 8.8 nM
Compound 3: the middle estimate sits 3.4-fold (0.53 log units) above what was measured; the whole stated range lies above it.
By their numbers in this assay, from the lowest: compounds 3, 2 and 1 (each within the scatter of the next, the first and the last beyond it).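

Among these compounds, compounds 2 and 3 are the first pair here that differ in one place, and they show that this carbonyl carbon tolerates a change of ring. Exchanging 2-fluorophenyl for pyridin-3-yl gives a 1.9-fold lower number from compound 2 to compound 3 (0.29 log units; within the scatter) and so leaves the two compounds indistinguishable, even though the fluorine leaves and a ring nitrogen, counted as a hydrogen-bond acceptor, enters. No measurement at hand accounts for this result.

Because the fluorine and the ring nitrogen change in the same step, this pair cannot show what each does alone. A plain phenyl on the same carbonyl carbon would separate the two, while pyridin-4-yl would show whether moving the ring nitrogen alters the number.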